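A halogen swap on the amide aryl group

A few compounds are considered here, and "the series" means these few. Any claim that something is new, unique, unknown or untested is made for them only; others in the source may bear on it.

Compound 1 `COc1cc2ncnc(Nc3ccc(NC(=O)c4ccccc4OC)cc3)c2cc1OC` (> 100000 nM) a limit of the assay
Compound 2 `COc1cc2ncnc(Nc3ccc(NC(=O)c4ccccc4Cl)cc3)c2cc1OC` (36000 nM)
Compound 3 `COc1cc2ncnc(Nc3ccc(NC(=O)c4c(F)cccc4F)cc3)c2cc1OC` (24000 nM)

Among the measured compounds shown here, in a functional assay on MCF7 cells (Homo sapiens) for inhibition, read by MTT assay (on this read-out lower numbers stand for stronger inhibition and higher numbers for weaker inhibition), compound 3 lies within the scatter of compound 2, and these two hold the only actual numbers. The entry for compound 1 is a limit. Compound 4 `COc1cc2ncnc(Nc3ccc(NC(=O)c4cc(F)ccc4Br)cc3)c2cc1OC` differs from compound 3 by 2-bromo-5-fluorophenyl in place of 2,6-difluorophenyl on a carbonyl carbon with 2-bromo-5-fluorophenyl in place of 2,6-difluorophenyl on a carbonyl carbon. The closest guide is a 1.5-fold lower number from compound 2 to compound 3 (0.18 log units; within the scatter) between two halogen-bearing aryl groups. The larger steps of an at least 2.7-fold lower number from compound 1 to compound 2 (0.44 log units; beyond the scatter) and an at least 4.1-fold lower number from compound 1 to compound 3 (0.61 log units; beyond the scatter) both leave the 2-methoxyphenyl of compound 1 and so fit this swap less well. In this assay the expected result is a 1.0-fold higher number from compound 3 to compound 4 (0.02 log units; within the scatter) with no step beyond the scatter. Compound 4 is estimated at 25000 nM with an expected range from 10000 nM to 60000 nM in this measurement.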

Compound 4, half-maximal inhibitory concentration: 26000 nM
Compound 4: middle estimate off by 1.0-fold (0.02 log units), on the low side, within the range that was stated.
By their numbers in this assay, from the lowest: compounds 3, 4 and 2 (each within the scatter of the next). At a limit, above all of these: compound 1.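

In this assay, a third halogen-bearing aryl group on this carbonyl carbon changes nothing that can be told from scatter: a 1.1-fold higher number from compound 3 to compound 4 (0.03 log units; within the scatter), and a 1.4-fold lower number from compound 2 to compound 4 (0.14 log units; within the scatter). Set against the 2-methoxyphenyl group, 2-bromo-5-fluorophenyl shows the same kind of gap as the other two halogen-bearing groups, with an at least 3.8-fold lower number from compound 1 to compound 4 (0.58 log units; beyond the scatter). The entry for compound 1 is a limit, not a number: the limit of > 100000 nM in this assay, at which 1 of the 4 values shown sits.

On these data alone, whether an amine or a carboxylic acid on this aryl ring would move the value beyond the scatter stays open. As far as these compounds go, the separate parts played by the bromine and the fluorine of compound 4 also stay open.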